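The compounds below may be only part of what the source reports. "The series", "measured", "known", "first", "only" and "open" are said of these compounds alone.

Compound 3, `O=C(O)C[C@@H](NC(=O)[C@@H]1CCN1S(=O)(=O)c1cc(Cl)cc(Cl)c1)c1ccc(OC(F)F)cc1`, gives 1.3 nM in an assay on RPMI-8866 cells for inhibition of integrin alpha-4/beta-1 (Homo sapiens) (a lower number here means a stronger inhibitor, a higher number a weaker inhibitor), and stands second highest of the three numbers recorded so far. Its neighbours are compound 1, `O=C(O)C[C@@H](NC(=O)[C@@H]1CCN1S(=O)(=O)c1cc(Cl)cc(Cl)c1)c1ccc(F)cc1`, which gives 3.2 nM, and compound 2, `O=C(O)C[C@@H](NC(=O)[C@@H]1CCN1S(=O)(=O)c1cc(Cl)cc(Cl)c1)c1ccc(OC2CCCC2)cc1`, which gives 0.5 nM; the steps were a 2.5-fold lower number from compound 1 to compound 3 (0.39 log units; beyond the scatter) and a 2.6-fold higher number from compound 2 to compound 3 (0.41 log units; beyond the scatter). Compound 4, `COc1ccc([C@@H](CC(=O)O)NC(=O)[C@@H]2CCN2S(=O)(=O)c2cc(Cl)cc(Cl)c2)cn1`, differs from compound 3 by 6-methoxypyridin-3-yl in place of 4-(difluoromethoxy)phenyl on a saturated chain carbon bound to an amide-type nitrogen and a saturated chain carbon. The three measured steps, including a 6.4-fold lower number from compound 1 to compound 2 (0.81 log units; beyond the scatter), all alter only the group on the aromatic ring and were modest in size; none exchanges the ring itself, so their bearing on this change is indirect. A modest step in this assay is therefore expected, most likely toward a somewhat higher number, given as a 1.9-fold higher number from compound 3 to compound 4 (0.28 log units; within the scatter). Compound 4 is estimated at 2.5 nM, within 0.7 nM to 9 nM.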

Compound 4, half-maximal inhibitory concentration: 3 nM
Estimate against measurement, compound 4: 1.2-fold (0.08 log units) below; low and high end bracket the measured number.
By their numbers in this assay, from the lowest: compound 2; then compound 3; then compounds 4 and 1 (each within the scatter of the next).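

Exchanging the ring itself on the saturated chain carbon gives, in this assay, a 2.3-fold higher number from compound 3 to compound 4 (0.36 log units; beyond the scatter), so this position still accepts a ring with a hetero atom at a modest cost. Against the 4-fluorophenyl group the exchange gives a 1.1-fold lower number from compound 1 to compound 4 (0.03 log units; within the scatter), leaving compound 1 and compound 4 level. No measurement here offers an explanation for either step.

Going by these compounds, the step changes the ring and the alkoxy group together, so the share of each stays unknown. A 4-methoxyphenyl group would separate them, and a cyclopentyloxy group on the pyridine ring remains untested in the compounds shown.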